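A few compounds are considered here, and "the series" means these few. Any claim that something is new, unique, unknown or untested is made for them only; others in the source may bear on it.

Compound 1 `COc1ccc(/C=C2/S/C(=N/c3ccccc3C)NC2=O)cc1`: 195000 nM
Compound 2 `Cc1ccc(N=C2NC(=O)/C(=C\c3ccc(N(C)C)cc3)S2)cc1`: > 100000 nM

In an ADME assay on cells (Homo sapiens) for antiproliferative activity (a higher number here means a weaker inhibitor, a lower number a stronger inhibitor), compound 2 reads > 100000 nM, which is a limit of the assay and not a number. Compound 1 does give a number, 195000 nM, so both measured compounds sit at the weak end of the readings so far.

The next compound to be tested is compound 3 `CN(C)c1ccc(/C=C2/SC(=Nc3ccccc3Cl)NC2=O)cc1`. It carries 2-chlorophenyl in place of 4-methylphenyl on a double-bonded nitrogen. For the measured compounds named here, no measured pair shows what a change of this kind does in this assay, so the data offer no direct guide to its size. The expected step, a step that the limit leaves unreadable from compound 2 to compound 3, is none beyond the usual scatter, in either direction. Going by the values given here, this expectation rests on compound 1 at 195000 nM, the only true number available. For compound 3 the estimated value is 120000 nM, with an expected range of 40000 nM to 300000 nM.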

Compound 3, half-maximal inhibitory concentration: > 100000 nM
Compound 3 ended at the assay's limit (the forecaster's own chance of this, stated with the estimate: 50%); the middle value does not contradict the limit.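

In this assay compound 3 reads > 100000 nM, which is a limit of the assay and not a number. Compound 2 also stands at a limit, so no step between compound 2 and compound 3 can be read: the limit of > 100000 nM in this assay, at which 2 of the 3 values shown sit.

The compounds shown leave open whether 2-chlorophenyl in place of 4-methylphenyl changes the activity at all.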